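The source may report more compounds than this note shows. Statements on the series, on what has been measured and on what is new or still open speak of the compounds shown alone.

Compound 2, `Nc1ncnc2c1c(-c1cc(C3CC3)on1)nn2C1CCCCC1`, gives 2 nM in an assay on isolated protein for inhibition of proto-oncogene tyrosine-protein kinase receptor Ret (Homo sapiens), read by radiometric assay and 33P incorporation, in the presence of a further agent that is not named here (a lower number here means a stronger inhibitor, a higher number a weaker inhibitor), the lowest number among the three compounds measured. Compound 1, `CC(C)n1nc(-c2cc(C(C)(C)C)on2)c2c(N)ncnc21`, comes nearest with 210 nM in this assay, and compound 3, `CC(C)n1nc(/C=N/OCc2ccccc2)c2c(N)ncnc21`, lies furthest away with 8330 nM; both gaps are beyond the usual scatter. Compound 1 and compound 2 differ in two places at once, so their two values can only be set side by side and not read as a single step.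

Compound 4, `Cn1nc(-c2cc(C3CC3)on2)c2c(N)ncnc21`, has not yet been measured. It differs from compound 2 in one place: methyl in place of cyclohexyl on an aromatic nitrogen. Among the compounds with values here, no measured pair isolates this change. Compound 2 with its cyclohexyl group gives 2 nM and compound 1 with its isopropyl group gives 210 nM, so a smaller group at this place has so far gone with a higher number; compound 4 is therefore expected to sit higher than compound 2, a step of a 75-fold higher number from compound 2 to compound 4 (1.88 log units; beyond the scatter) in this assay, beyond the scatter. Compound 4 is estimated at 150 nM, within a range from 30 nM to 800 nM.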

Compound 4, half-maximal inhibitory concentration: 27 nM
Compound 4: the middle estimate sits 5.6-fold (0.74 log units) above what was measured, and the stated range ends above it.
By their numbers in this assay, from the lowest: compound 2; then compound 4; then compound 1; then compound 3.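

With the 5-cyclopropyl-1,2-oxazol-3-yl group held fixed, the change from cyclohexyl to methyl on the aromatic nitrogen can now be read as a single step, a 14-fold higher number from compound 2 to compound 4 (1.13 log units; beyond the scatter), in this assay. Within the data shown here, this gives the first isolated reading at this position: the six-carbon ring goes with the lower number, while compound 4, with its single carbon at this place, still gives 27 nM, so the cyclohexyl ring is not needed for a value in the nanomolar range. Nothing shown here bears on what lies behind this step.

With only two groups compared directly at this position, the compounds shown leave open where an ethyl or cyclopentyl group would fall, and whether a piperidine ring would follow the same trend. They also leave open whether the step would keep its size with a tert-butyl group in place of the cyclopropyl group.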